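This account rests on a few compounds, and the source may have more. Where it says the series, first, only, none or still open, it means among the compounds named here.

Measured compounds:
compound 1, `CN(C)C(=O)C1CCN(c2nc(-c3cc(F)c(Cl)cc3F)nc3c2CS(=O)(=O)C3)CC1` — 1 mg/kg
compound 2, `O=C(O)C1CCN(c2nc(-c3cc(F)c(Cl)cc3F)nc3c2CS(=O)(=O)C3)CC1` — > 3 mg/kg; this value is a limit of the assay
compound 3, `O=S1(=O)Cc2nc(-c3cc(F)c(Cl)cc3F)nc(N3CCC(O)CC3)c2C1` — 1 mg/kg

In a functional assay on the whole organism (blood, strain ICR) with Mus musculus as the target, in the glucose tolerance test, with a stated time of 30 min (on this read-out higher numbers stand for an effect only at larger amounts of compound and lower numbers for an effect already at smaller amounts), compound 3 stands level with compound 1 at the digits shown. The value of compound 2 is a limit, not a number. Compound 4, `O=S1(=O)Cc2nc(-c3cc(F)c(Cl)cc3F)nc(N3CCC(CCO)CC3)c2C1`, differs from compound 3 by 2-hydroxyethyl in place of hydroxy on a saturated ring carbon. For the measured compounds named here, the measured steps that touch this ring carbon are no change at the digits printed from compound 1 to compound 3 (within the scatter) and an at least 3.0-fold lower number from compound 2 to compound 3 (0.47 log units; beyond the scatter); neither tests a longer chain carrying the hydroxy, and no measured pair does. The hydroxy itself stays, so in this assay no step beyond the scatter is expected, no change at the digits printed from compound 3 to compound 4 (within the scatter). Compound 4 is therefore estimated at 1 mg/kg, with a range from 0.5 mg/kg to 3 mg/kg.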

Compound 4, minimum effective dose: 1 mg/kg
Compound 4: the middle estimate sits on the measured number at the digits printed; measured number inside the range.
By their numbers in this assay, from the lowest: compounds 1, 3 and 4 (each within the scatter of the next). At a limit, above all of these: compound 2.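

In this assay, moving the hydroxy out onto a 2-hydroxyethyl chain on this saturated ring carbon gives no change at the digits printed from compound 3 to compound 4 (within the scatter), so this position accepts the longer hydroxy-bearing group. Against the dimethylcarbamoyl group the same change gives no change at the digits printed from compound 1 to compound 4 (within the scatter), while against the carboxy group it gives an at least 3.0-fold lower number from compound 2 to compound 4 (0.47 log units; beyond the scatter). That last step starts from a limit of compound 2, not a number: the limit of > 3 mg/kg in this assay, at which 1 of the 4 values shown sits.

A plain ethyl group or an amine on this ring carbon would show whether the hydroxy is needed at all. Going by these compounds, how long a hydroxy-bearing chain this position accepts also remains open, as a 3-hydroxypropyl chain would test.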